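Moving One Fluorine: 2,3-Difluorophenyl to 2,5-Difluorophenyl

The compounds below may be only part of what the source reports. "The series", "measured", "known", "first", "only" and "open" are said of these compounds alone.

Compound 1 `C[C@]1(CN2CCc3nc(C4CCCCC4)ccc3C2)Cn2cc([N+](=O)[O-])nc2O1`, compound 2 `C[C@]1(CN2CCc3nc(-c4ccc(C#N)cc4)ccc3C2)Cn2cc([N+](=O)[O-])nc2O1` and compound 3 `C[C@]1(CN2CCc3nc(-c4cccc(F)c4F)ccc3C2)Cn2cc([N+](=O)[O-])nc2O1` share one core and differ in the group attached to it. Toxicity to cells was tested in an ADME assay on Vero cells (Chlorocebus sabaeus) for cytotoxicity, read by MTT assay, with a stated time of 72 h; on this read-out higher numbers stand for lower toxicity in this test and lower numbers for higher toxicity in this test. In this assay compound 1 gives "not determined" (no result reported). In the same test compound 2 gives "not determined" (no result reported). Compound 3 gives > 32 ug/mL, which is a limit of the assay and not a number. The evidence so far comes down to this: the limit of > 32 ug/mL in this assay, at which 1 of the 3 values shown sits.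

Compound 4 `C[C@]1(CN2CCc3nc(-c4cc(F)ccc4F)ccc3C2)Cn2cc([N+](=O)[O-])nc2O1` has the same atoms as compound 3, joined differently: 2,5-difluorophenyl in place of 2,3-difluorophenyl on an aromatic carbon. In short, 2,5-difluorophenyl stands in place of 2,3-difluorophenyl on an aromatic carbon. Among the measured compounds shown here, no pair of measured compounds shows what such a change does. The expected step that the limit leaves unreadable from compound 3 to compound 4 is none beyond the usual scatter, and a second limit reading is quite likely. Compound 4 is expected to give about 40 ug/mL, with an estimated range of 24 ug/mL to 64 ug/mL.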

Compound 4, half-maximal cytotoxic concentration: > 32 ug/mL
Compound 4: no number, only a limit (the forecaster's own chance of this, stated with the estimate: 85%); the middle value does not contradict the limit.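

In this assay compound 4 gives > 32 ug/mL, which is a limit of the assay and not a number. Among the compounds shown here, compound 3 also gives only a limit, so no step from compound 3 to compound 4 can be read. The compounds shown leave open whether 2,5-difluorophenyl and 2,3-difluorophenyl differ at all in toxicity to these cells.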